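The compounds below may be only part of what the source reports. "The series", "measured", "known", "first", "only" and "open" are said of these compounds alone.

Compound 2 `CO[C@@H]1C[C@@H](C(=O)N2CCC(N3CCCC3)CC2)N(C(=O)NCc2ccc(C(=O)N3CCCCc4sccc43)cc2Cl)C1` gives 1100 nM in an assay on isolated protein with Vasopressin V2 receptor (Homo sapiens) as the target; a higher number here means that more compound is needed for the effect, a lower number that less compound is needed; compound 1 `CO[C@@H]1C[C@@H](C(=O)NCCN(C)C)N(C(=O)NCc2ccc(C(=O)N3CCCCc4sccc43)cc2Cl)C1` gives 1800 nM, and the two numbers sit within the scatter of each other. Compound 3 `CO[C@@H]1C[C@@H](C(=O)N2CCCN(C)CC2)N(C(=O)NCc2ccc(C(=O)N3CCCCc4sccc43)cc2Cl)C1` carries 4-methyl-1,4-diazepan-1-yl in place of 4-(pyrrolidin-1-yl)piperidin-1-yl on a carbonyl carbon. Going by the values given here, the only comparison that bears on this position is the amide change a 1.6-fold lower number from compound 1 to compound 2 (0.21 log units; within the scatter), which stayed within the scatter. On that basis the expected step from compound 2 to compound 3 is small, a 1.1-fold higher number from compound 2 to compound 3 (0.04 log units; within the scatter), with no direction beyond the scatter. Compound 3 is therefore estimated at 1200 nM, with a range from 500 nM to 3000 nM.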

Compound 3, half-maximal effective concentration: 1300 nM
Compound 3: middle estimate off by 1.1-fold (0.03 log units), on the low side; low and high end bracket the measured number.
By their numbers in this assay, from the lowest: compounds 2, 3 and 1 (each within the scatter of the next).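

Placing 4-methyl-1,4-diazepan-1-yl on the carbonyl carbon changes little in this assay, with a 1.2-fold higher number from compound 2 to compound 3 (0.07 log units; within the scatter) and a 1.4-fold lower number from compound 1 to compound 3 (0.14 log units; within the scatter). The group has fewer heavy atoms than 4-(pyrrolidin-1-yl)piperidin-1-yl, yet this group, that one and (2-(dimethylamino)ethyl)amino all lie within the scatter of one another at this place. No measurement shown here accounts for this result.
All three groups carry an amine beyond the amide nitrogen. On these data alone, whether a carboxylic acid or a morpholine at this place would stay in the same range remains open.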